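The source may hold more compounds than are shown below. What is called first, only, known or untested is meant among the compounds shown, and "the series" means these compounds.

In the study at hand, the compounds were tested in a functional assay on cells (Mast cell, Rattus norvegicus) for inhibition, with a stated time of 15 min; on this read-out lower numbers stand for an effect already at smaller amounts and higher numbers for an effect only at larger amounts of compound. Compound 1 `O=C(Nc1nnn[nH]1)c1ccc2occc(=O)c2c1` gives 0.7 ug/mL, and compound 2 `Cc1c(C(=O)Nc2nnn[nH]2)oc2ccccc2c1=O` gives 0.4 ug/mL; the two numbers lie within the usual scatter of each other, so no order between them can be claimed. Compound 1 therefore stands at the higher of the two numbers reported, with compound 2 as its nearest neighbour. For the measured compounds named here, compound 3 `O=C(O)CCNC(=O)c1cc(=O)c2ccccc2o1` reaches only a limit of the assay, > 18 ug/mL, and no number is known for it; this limit is the one value of the three that sits at the limit of > 18 ug/mL in this assay, at which 1 of the 3 values shown sits.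

Compound 4 `O=C(O)c1ccc2occc(=O)c2c1` has not yet been measured. Against compound 1 it shows the change (hydroxy in place of (1H-tetrazol-5-yl)amino on a carbonyl carbon).

Going by the values given here, no measured pair isolates this change, so the expectation rests on the values of compounds 1 and 2 and on the limit seen for compound 3. The step of an 11-fold higher number from compound 1 to compound 4 (1.06 log units; beyond the scatter) is expected to run toward higher numbers, well beyond the scatter. Compound 4 is thus estimated at 8 ug/mL, with a range from 1.5 ug/mL to 40 ug/mL, and a real chance that only a limit is reported.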

Compound 4, concentration for half-maximal effect: > 18 ug/mL
Compound 4: a limit, no number; the forecaster's own chance of this, stated with the estimate: 40%; at least 2.2-fold (0.35 log units) between middle value and limit.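

For the compounds shown here, until now no pair of compounds isolated a change on this carbonyl carbon. Compound 1 and compound 4 now do, and in this assay hydroxy in place of (1H-tetrazol-5-yl)amino gives a step that reads an at least 25-fold higher number from compound 1 to compound 4 (1.41 log units; beyond the scatter) and counts as large, so within this pair a measured number goes with the (1H-tetrazol-5-yl)amino group and not with the core alone. Compound 4 reaches only a limit of the assay, the same limit as compound 3: the limit of > 18 ug/mL in this assay, at which 2 of the 4 values shown sit.

Going by these compounds, the step therefore has a lower bound only, and its full size stays unknown. The compounds shown also leave open whether a plain amine, a methyl ester or an amide bearing a carboxylic acid on a short chain, placed on this carbonyl carbon of the same core, would keep a measurable number.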